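Swapping a phenethyl arm for benzylsulfanyl on a benzimidazole-type core

The source may report more compounds than this note shows. Statements on the series, on what has been measured and on what is new or still open speak of the compounds shown alone.

Measured compounds:
- compound 1, `Clc1ccc2[nH]c(SCc3ccccc3CCc3ccccc3)nc2c1`: 47%
- compound 2, `c1ccc(CCc2ccccc2CSc2nc3ccccc3[nH]2)cc1`: 43%

Both compounds were tested in an assay on isolated protein for inhibition of Indoleamine 2,3-dioxygenase 1 (Homo sapiens), with a stated time of 60 min, tested at 10 uM; on this read-out higher numbers stand for more inhibition at the one concentration tested (going by the name of the read-out) and lower numbers for less inhibition. Compound 1 stands highest of the two numbers, but its nearest neighbour, compound 2, lies within the scatter of it: the step of a number 4 percentage points lower from compound 1 to compound 2 (within the scatter), hydrogen in place of chloro on an aromatic carbon, makes no difference that can be trusted.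

Compound 3, `Clc1ccc2[nH]c(SCc3ccccc3SCc3ccccc3)nc2c1`, has not been measured yet. It differs from compound 1 by benzylsulfanyl in place of phenethyl on an aromatic carbon. Among the compounds with values here, no measured step touches this kind of change; the only step on record concerns the chloro group, and that one stayed within the scatter. With no evidence pointing either way, the expectation is that the step of a number 2 percentage points lower from compound 1 to compound 3 (within the scatter) stays within the scatter. Compound 3 is therefore estimated at 45%, with a range from 20% to 70%.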

Compound 3, a percentage reported as inhibition, at one concentration (the size of the read-out at that concentration, not a potency): 19%
For compound 3 the middle estimate is 26 percentage points above the measured one; measured number below the stated range.
By their numbers in this assay, from the lowest: compound 3; then compounds 2 and 1 (each within the scatter of the next).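

This position is more sensitive than the chloro site on the shared core. In this assay, benzylsulfanyl in place of phenethyl, on an aromatic carbon ortho to a large group, gives a number 28 percentage points lower from compound 1 to compound 3 (beyond the scatter) even though the two groups have the same count of heavy atoms and the same ring of carbon only. They differ in that benzylsulfanyl brings a sulfur and a hydrogen-bond acceptor, but no measurement at hand says what lies behind the lower number.

On these data alone, it remains open whether the sulfur itself accounts for the fall, or whether another arm at this position, such as benzyloxy or a benzylamine, would stay close to compound 1 at 47%. The compounds shown also leave open whether removing the chloro group from compound 3 would change its number.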